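Compound 3 to compound 4: ring out, open chain in

The source may report more compounds than this note shows. Statements on the series, on what has been measured and on what is new or still open speak of the compounds shown alone.

Measured in a functional assay on NCI-H23 cells (Homo sapiens) for antiproliferative activity, read by sulforhodamine B assay; a lower number here means a stronger inhibitor of growth, a higher number a weaker inhibitor of growth:
- compound 1 `CC(C)=CCOc1cccc(O)c1C(=O)/C=C/c1ccc(O)cc1` gives > 30000 nM as a limit
- compound 2 `O=C(/C=C/c1ccc(O)cc1)c1c(O)cccc1OCCC1CCCCC1` gives > 30000 nM as a limit
- compound 3 `O=C(/C=C/c1ccc(O)cc1)c1c(O)cccc1OCC1CCCC1` gives 3160 nM as a number

Going by the values given here, compound 3 holds the only true number so far, at 3160 nM in this series. Compound 1 and compound 2 stand at the limit of > 30000 nM in this assay, at which 2 of the 3 values shown sit, without a number. The change to compound 4 `CCCCOc1cccc(O)c1C(=O)/C=C/c1ccc(O)cc1` puts propyl in place of cyclopentyl, counted as propyl in place of cyclopentyl on a saturated chain carbon bound to an oxygen on an aromatic ring on a saturated chain carbon bound to an oxygen on an aromatic ring. The steps of an at least 9.4-fold lower number from compound 1 to compound 3 (0.97 log units; beyond the scatter) and an at least 9.4-fold lower number from compound 2 to compound 3 (0.97 log units; beyond the scatter) bear on it, and both favour the cyclopentyl group. Compound 1, the nearest open-chain comparison, gives > 30000 nM which is a limit. The expected step is a 4.7-fold higher number from compound 3 to compound 4 (0.68 log units; beyond the scatter) toward weaker growth inhibition in this assay and may end at the limit. The estimated value for compound 4 is 15000 nM with 4000 nM to 40000 nM as the expected range.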

Compound 4, concentration for 50% growth inhibition: > 30000 nM
Compound 4 ended at the assay's limit (the forecaster's own chance of this, stated with the estimate: 45%); middle value at least 2.0-fold (0.30 log units) from the limit.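

In this assay, propyl in place of cyclopentyl gives an at least 9.4-fold higher number from compound 3 to compound 4 (0.97 log units; beyond the scatter), so a saturated open chain at this place loses growth inhibition, as the unsaturated chain of compound 1 does not show. Compound 4 stands at > 30000 nM, which is a limit. Only the cyclopentyl of compound 3 yields a number so far, and the steps from compound 1 and compound 2 to compound 4 cannot be read: the limit of > 30000 nM in this assay, at which 3 of the 4 values shown sit.

Still open, from the compounds shown here alone, is whether a cyclobutyl or a cyclohexyl on the same saturated chain carbon keeps a number. Going by these compounds, a longer chain such as hexyl is equally open.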